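Replacing 1,3-benzothiazol-2-yl with trifluoromethyl: a solubility estimate

The compounds below may be only part of what the source reports. "The series", "measured", "known", "first", "only" and "open" are said of these compounds alone.

Two closely related compounds have been measured so far in a physicochemical assay for solubility, read by spectrophotometry, in phosphate buffer, measured as kinetic solubility, with a stated time of 18 h, at pH 7.4; a lower number here means a less soluble compound, a higher number a more soluble compound. Compound 1 (`O=C(Nc1ccc(O)c(-c2nc3ccccc3s2)c1)c1cc([N+](=O)[O-])ccc1Cl`) gives 23 nM. Compound 2 (`O=C(Nc1ccc(Cl)c(-c2nc3ccccc3s2)c1)c1cc([N+](=O)[O-])ccc1Cl`) gives 410 nM, the higher of the two numbers. For the measured compounds named here, the one measured step, chloro in place of hydroxy on an aromatic carbon, is an 18-fold higher number from compound 1 to compound 2 (1.25 log units; beyond the scatter). That is a large move for a single swap, and it lies beyond the usual scatter. Compound 3 (`O=C(Nc1ccc(Cl)c(C(F)(F)F)c1)c1cc([N+](=O)[O-])ccc1Cl`) keeps the chloro of compound 2 but carries trifluoromethyl in place of 1,3-benzothiazol-2-yl on an aromatic carbon. Going by the values given here, no measured step covers this swap, since the earlier one happened at a different place on the molecule. It serves only as a rough yardstick for how far one change can shift this assay. With a much smaller group entering, a rise more modest than that yardstick is expected, though the direction remains uncertain. The estimated change is a 4.9-fold higher number from compound 2 to compound 3 (0.69 log units; beyond the scatter). Compound 3 is estimated at 2000 nM, with an expected range from 400 nM to 10000 nM.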

Compound 3, solubility: 580 nM
Beside the measured number, compound 3's estimate is 3.4-fold (0.54 log units) above it; the range from low to high includes it.
By their numbers in this assay, from the lowest: compound 1; then compounds 2 and 3 (each within the scatter of the next).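

In this assay, this position, on an aromatic carbon ortho to a chloro group, tolerates a large change in the group it carries: trifluoromethyl in place of 1,3-benzothiazol-2-yl gives a 1.4-fold higher number from compound 2 to compound 3 (0.15 log units; within the scatter). The group that leaves has 9 heavy atoms, with a five-membered and a six-membered aromatic ring, and the group that enters has 4 heavy atoms and no ring, yet the two numbers cannot be told apart, whereas the smaller-looking swap at another place on the molecule gave an 18-fold higher number from compound 1 to compound 2 (1.25 log units; beyond the scatter). Nothing available here explains why this exchange leaves the read-out within the scatter.

The compounds shown leave open whether a carboxylic acid or an amine at this position would also stay within the scatter of compound 3, as only two groups can be compared here. Going by these compounds, it is also open whether hydroxy in place of chloro would shift the number as far with trifluoromethyl present as it did with 1,3-benzothiazol-2-yl present.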